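The source may report more compounds than this note shows. Statements on the series, on what has been measured and on what is new or still open speak of the compounds shown alone.

In a functional assay on RAW264.7 cells (Mus musculus) for inhibition, with a stated time of 1 h (a lower number here means a stronger inhibitor, a higher number a weaker inhibitor), compound 3 (`CCCCCCCCCCCCCCC(=O)C(=O)N[C@@H](CCCC)COCC(=O)O`) gives 25000 nM, level with compound 1 (`CCCCCCCCCCCCCCC(=O)C(=O)N[C@@H](CCCC)CCC(=O)O`) at 25000 nM, while compound 2 (`CCCCCCCCCCCCCCC(=O)C(=O)N[C@@H](CCCC)CCCC(=O)O`) gives 2000 nM. Compound 4 (`CCCCCCCCCCCCCCC(=O)C(=O)N[C@H](/C=C/C(=O)O)CCCC`) carries 2-carboxyethenyl in place of (carboxymethoxy)methyl on a saturated chain carbon bound to an amide-type nitrogen and a saturated chain carbon. For the measured compounds named here, three measured steps bear on this change. The first is small, no change at the digits printed from compound 1 to compound 3 (within the scatter). The other two are large and both involve compound 2: a 13-fold lower number from compound 1 to compound 2 (1.10 log units; beyond the scatter) and a 13-fold higher number from compound 2 to compound 3 (1.10 log units; beyond the scatter). Compound 4 does not carry the 2-carboxyethyl group of compound 2, so no step beyond the scatter is expected in this assay. The estimated step is a 1.3-fold lower number from compound 3 to compound 4 (0.10 log units; within the scatter). For compound 4 the expected value is 20000 nM, within an estimated range of 6000 nM to 60000 nM.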

Compound 4, half-maximal inhibitory concentration: 7000 nM
Compound 4: middle estimate off by 2.9-fold (0.46 log units), on the high side; the measured number falls inside the stated range.
By their numbers in this assay, from the lowest: compound 2; then compound 4; then compounds 1 and 3 (each within the scatter of the next).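

On this carbon, the chain length of compound 1 no longer fixes the result in this assay: 2-carboxyethenyl in place of 2-carboxyethyl gives a 3.6-fold lower number from compound 1 to compound 4 (0.55 log units; beyond the scatter), and in place of (carboxymethoxy)methyl it gives a 3.6-fold lower number from compound 3 to compound 4 (0.55 log units; beyond the scatter). The change recovers only part of the ground held by 3-carboxypropyl, with a 3.5-fold higher number from compound 2 to compound 4 (0.54 log units; beyond the scatter). Nothing measured here explains these steps. The compounds shown leave open how a longer chain carrying both the double bond and the carboxylic acid would compare, and whether an amine could stand in place of that acid.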